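The source may report more compounds than this note shows. Statements on the series, on what has been measured and on what is new or still open speak of the compounds shown alone.

In a physicochemical assay for solubility, in phosphate buffer (a lower number here means a less soluble compound, a higher number a more soluble compound), compound 3 (`C[C@H]1CN([C@@H](C)CO)C(=O)c2cccc(NC(=O)c3ccncc3)c2O[C@@H]1CN(C)Cc1ccccc1`) gives 100000 nM. Compound 2 (`C[C@H](CO)N1C[C@H](C)[C@H](CN(C)Cc2ccc(Oc3ccccc3)cc2)Oc2c(NC(=O)c3ccncc3)cccc2C1=O`) gives 98000 nM, within the scatter of compound 3, whereas compound 1 (`C[C@H](CO)N1C[C@H](C)[C@@H](CN(C)Cc2ccc(Oc3ccccc3)cc2)Oc2c(NC(=O)c3ccncc3)cccc2C1=O`) gives 2000 nM, far under the other two. Compound 4 (`C[C@H]1CN([C@@H](C)CO)C(=O)c2cccc(NC(=O)c3ccncc3)c2O[C@@H]1CN(C)Cc1ccc(Oc2ccccc2)cc1`) departs from compound 3 by a single change: phenoxy in place of hydrogen on an aromatic carbon. Compounds 1 and 2 already carry this phenoxy group, so they are the closest guide. For the measured compounds named here, the only measured step among them is a 49-fold higher number from compound 1 to compound 2 (1.69 log units; beyond the scatter), which is due to the fact that compounds 1 and 2 differ only in the configuration as drawn. That step does not measure the effect of adding phenoxy, but it shows that compounds bearing the group can differ widely in this assay. Compound 1 at 2000 nM suggests a fall from compound 3, while compound 2 at 98000 nM warns that the fall may be small. A drop beyond the scatter is therefore expected, estimated as a 10-fold lower number from compound 3 to compound 4 (1.00 log units; beyond the scatter). For compound 4 the expected value is 10000 nM, with an estimated range from 1500 nM to 70000 nM.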

Compound 4, solubility: 1000 nM
For compound 4 the middle estimate is 10-fold (1.00 log units) above the measured one, and the stated range ends above it.
By their numbers in this assay, from the lowest: compounds 4 and 1 (each within the scatter of the next); then compounds 2 and 3 (each within the scatter of the next).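

In this assay, for the compounds shown here, phenoxy in place of hydrogen on this aromatic carbon gives a 100-fold lower number from compound 3 to compound 4 (2.00 log units; beyond the scatter), a direct reading of this change that the earlier compounds did not offer. Among the compounds carrying phenoxy, configuration alone gives a 98-fold lower number from compound 2 to compound 4 (1.99 log units; beyond the scatter): the fact that compounds 2 and 4 differ only in the configuration as drawn. Going by these compounds alone, compound 2 is the one phenoxy compound here with a high number, while a 2.0-fold lower number from compound 1 to compound 4 (0.30 log units; within the scatter) places compound 4 with compound 1: the fact that compounds 1 and 4 differ only in the configuration as drawn.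

From the compounds shown here alone, it remains open whether a smaller group at this carbon, such as methoxy, or one such as an amine or a carboxylic acid, would give a step of similar size. Also open, going by these compounds, is how the compounds with hydrogen at this carbon would read in the configurations of compounds 1 and 2.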